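This account rests on a few compounds, and the source may have more. Where it says the series, first, only, none or still open, it means among the compounds named here.

Measured compounds:
- compound 1, `COC(CN(c1ccccc1CO)S(=O)(=O)c1ccc([N+](=O)[O-])cc1)n1cc(F)c(=O)[nH]c1=O`: 55200 nM
- compound 2, `COC(CN(c1ccccc1CO)S(=O)(=O)c1ccc([N+](=O)[O-])cc1)n1cnc2c(Cl)ncnc21`: 18700 nM

In a functional assay on MCF7 cells (Homo sapiens) for antiproliferative activity (on this read-out lower numbers stand for stronger inhibition and higher numbers for weaker inhibition), compound 1 gives 55200 nM, the highest of the two numbers recorded. Among the measured compounds shown here, its only neighbour is compound 2, and the change between them, a larger bicyclic group with two rings in place of the single six-membered ring on the chain carbon, gave a 3.0-fold lower number from compound 1 to compound 2 (0.47 log units; beyond the scatter).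

Compound 3, `COC(CN(c1ccccc1CO)S(=O)(=O)c1ccccc1N)n1cc(F)c(=O)[nH]c1=O`, has not yet been measured in this assay. It differs from compound 1 at a different place: 2-aminophenyl in place of 4-nitrophenyl on a sulfonyl sulfur. For the measured compounds named here, no measured step touches the group on the sulfonyl sulfur, so the one step recorded, from compound 1 to compound 2, tells nothing direct about this exchange. With the sulfonamide nitrogen and the rest of the shared core unchanged, compound 3 is expected to stay close to compound 1, with no step beyond the scatter as the likeliest outcome, so that a 1.1-fold lower number from compound 1 to compound 3 (0.04 log units; within the scatter) is the estimated step. Compound 3 is therefore estimated at 50000 nM in this assay, within a range of 15000 nM to 150000 nM.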

Compound 3, half-maximal inhibitory concentration: > 100000 nM
Compound 3 was reported as a limit; the forecaster's own chance of this, stated with the estimate: 25%; middle value at least 2.0-fold (0.30 log units) from the limit.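

The value for compound 3 is a limit of the assay and not a number: the limit of > 100000 nM in this assay, at which 1 of the 3 values shown sits. In this assay, the exchange of 4-nitrophenyl for 2-aminophenyl on a sulfonyl sulfur, the first change shown at this place, gives an at least 1.8-fold higher number from compound 1 to compound 3 (0.25 log units; that floor lies within the scatter). Only a floor is therefore known for this change, and because that floor lies within the scatter, the pair is not shown to differ, although the exchange clearly brought no lower number, unlike the earlier change on the chain carbon.

The compounds shown leave open how far the number rises, and whether it is the loss of the nitro group or the different arrangement on the ring that matters, as this one exchange alters both together. From the compounds shown here alone, a plain phenyl on the sulfonyl sulfur would begin to separate these two readings, and it also remains open whether 2-aminophenyl would act in the same way alongside the two-ring group of compound 2.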